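Oxime to nitrile on the difluorophenyl pyrrole core

The source may hold more compounds than are shown below. What is called first, only, known or untested is meant among the compounds shown, and "the series" means these compounds.

On these data alone, compound 2 `Cc1c(/C=N\O)cc(-c2ccc(S(C)(=O)=O)cc2)n1-c1ccc(F)c(F)c1` carries an oxime on the shared core, and in a functional assay on the whole organism (strain Swiss albino) for inhibition, with Mus musculus as the target, in the writhing test, with a stated time of 30 min, at a dose of 40 mg/kg by the oral route (a lower number here means a weaker effect, a higher number a stronger effect of the compound at the dose given), compound 2 gives "not determined" (no result reported), so its own level is unknown. Its neighbours give some footing: compound 1 `Cc1c(/C=N\O)cc(-c2ccc(S(C)(=O)=O)cc2)n1-c1cccc(F)c1` gives 45%, and compound 3 `Cc1c(/C=N\O)cc(-c2ccc(S(C)(=O)=O)cc2)n1-c1ccccc1` gives 57%, the step of a number 12 percentage points higher from compound 1 to compound 3 (beyond the scatter). Compound 4 `Cc1c(C#N)cc(-c2ccc(S(C)(=O)=O)cc2)n1-c1ccc(F)c(F)c1` replaces the oxime of compound 2 with a nitrile: a group of 2 heavy atoms (1 carbon, 1 nitrogen; no ring) in place of a group of 3 heavy atoms (1 carbon, 1 nitrogen, 1 oxygen; no ring), on an aromatic carbon. Going by the values given here, none of the measured steps concerns this exchange, and the effect of the second fluoro is unmeasured, so no direction can be read from the data. Compound 4 is therefore expected to land near the measured compounds, estimated at 40% in this assay, with a wide range from 15% to 65%.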

Compound 4, a percentage reported as inhibition, in the whole organism at one dose (the size of the read-out at that dose, not a potency): 57%
For compound 4 the middle estimate is 17 percentage points below the measured one; the measured number falls inside the stated range.
By their numbers in this assay, from the lowest: compound 1; then compounds 3 and 4 (each within the scatter of the next).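

Going by these compounds alone, with no number for compound 2 in this assay, no step from compound 2 to compound 4 can be read. The compounds shown leave open how exchanging the oxime for a nitrile changes the read-out on the same core. No supporting data explain the result for compound 4.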